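Cyclopentyl for oxolan-3-yl on the amine of compound 3

The compounds below may be only part of what the source reports. "The series", "measured", "known", "first", "only" and "open" are said of these compounds alone.

Compound 3 `CCCn1c(-c2ccccc2)nc2c(NC3CCOC3)ncnc21` stands second highest of the three numbers in an assay on CHO cells for displacement of a labelled ligand from adenosine receptor A1 (Homo sapiens), read by scintillation counting, with a stated time of 3 h (on this read-out lower numbers stand for stronger inhibition and higher numbers for weaker inhibition), giving 25 nM; compound 2 `CCCn1c(-c2ccccc2)nc2c(N)ncnc21` gives 101 nM and compound 1 `CCn1c(-c2ccccc2)nc2c(NC3CCCC3)ncnc21` gives 3.9 nM. For the measured compounds named here, the step from compound 2 to compound 3, a 4.0-fold lower number from compound 2 to compound 3 (0.61 log units; beyond the scatter), is the only measured step, and it does not touch the change now considered. Compound 4 `CCCn1c(-c2ccccc2)nc2c(NC3CCCC3)ncnc21` differs from compound 3 by cyclopentyl in place of oxolan-3-yl on a nitrogen on an aromatic ring. Compound 1 already carries cyclopentylamino and differs from compound 4 only in its chain; its value lies well under that of compound 3. Compound 4 is therefore expected to give a lower number, about a 5.0-fold lower number from compound 3 to compound 4 (0.70 log units; beyond the scatter). The estimate for compound 4 in this assay is 5 nM, within 1.5 nM to 15 nM.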

Compound 4, inhibition constant: 10 nM
Compound 4: the middle estimate sits 2.0-fold (0.30 log units) below what was measured; the measured number falls inside the stated range.
By their numbers in this assay, from the lowest: compound 1; then compound 4; then compound 3; then compound 2.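

Swapping the ring oxygen of oxolan-3-yl for carbon, at the same heavy-atom count, gives a 2.5-fold lower number from compound 3 to compound 4 (0.40 log units; beyond the scatter), while the whole gain of cyclopentyl over the free amine is a 10-fold lower number from compound 2 to compound 4 (1.00 log units; beyond the scatter). The chain counts as well: with cyclopentylamino held constant, the added methyl gives a 2.6-fold higher number from compound 1 to compound 4 (0.41 log units; beyond the scatter). Nothing available explains either effect.

Still open, from the compounds shown here alone, is how cyclohexyl or a hydroxyl on the cyclopentyl ring reads at the amine. Also open, going by these compounds, is whether a longer chain than those of compound 1 and compound 4 raises the number further.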